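Growth inhibition notes: from compound 2 to compound 3

This account rests on a few compounds, and the source may have more. Where it says the series, first, only, none or still open, it means among the compounds named here.

In an ADME assay on NIH3T3 cells (Mus musculus) for inhibition, read by sulforhodamine B assay, with a stated time of 48 h (on this read-out higher numbers stand for weaker inhibition of growth and lower numbers for stronger inhibition of growth), compound 2 `O=CNNC(=O)c1ccc2[nH]c(-c3ccc([N+](=O)[O-])o3)nc2c1` gives 62.5 ug/mL and compound 1 `O=C(NNC(=O)c1ccc2[nH]c(-c3ccc([N+](=O)[O-])o3)nc2c1)c1ccccc1` gives 31.3 ug/mL. Within the data shown here, these are the only two measured values, and they lie within the scatter of each other, so compound 2 has no meaningful rank yet.

Compound 3 `COc1ccc(C(=O)NNC(=O)c2ccc3[nH]c(-c4ccc([N+](=O)[O-])o4)nc3c2)cc1OC` carries 3,4-dimethoxyphenyl in place of hydrogen on a carbonyl carbon.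

Among the measured compounds shown here, one measured step bears on this change: a 2.0-fold higher number from compound 1 to compound 2 (0.30 log units; within the scatter). There, hydrogen takes the place of phenyl on a carbonyl carbon, so the step to compound 3 runs the opposite way, with an aromatic ring entering at the same place. For the measured compounds named here, that single comparison stays within the scatter, and no measured compound carries the two methoxy groups. Their contribution in this assay is therefore unknown, and a step beyond the scatter is not expected.

The expected change is a 1.6-fold lower number from compound 2 to compound 3 (0.19 log units; within the scatter).

For compound 3 the estimated value is 40 ug/mL, with an expected range of 15 ug/mL to 110 ug/mL.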

Compound 3, concentration for 50% growth inhibition: 31.3 ug/mL
Estimate against measurement, compound 3: 1.3-fold (0.11 log units) above; measured number inside the range.
By their numbers in this assay, from the lowest: compounds 1, 3 and 2 (each within the scatter of the next).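

Working notes on the carbonyl carbon whose other neighbour is an amide-type nitrogen: in this assay the entry of 3,4-dimethoxyphenyl in place of hydrogen gives a 2.0-fold lower number from compound 2 to compound 3 (0.30 log units; within the scatter) and so provides a second aromatic group at this place, again without a step beyond the scatter. Set against phenyl, the same group gives no change at the digits printed from compound 1 to compound 3 (within the scatter) and this is the first reading on the two methoxy groups, which make no difference that can be read here. Hydrogen, phenyl and 3,4-dimethoxyphenyl therefore all sit within the scatter of one another at this position, and no order can be drawn among compounds 1, 2 and 3. Nothing at hand gives a reason for this flat picture.

Still open, as far as these compounds go, is whether the position stays this flat with an amine or a carboxylic acid on the carbonyl carbon, or with a longer alkyl chain in place of the aromatic ring. Also open, from the compounds shown here alone, is whether these three compounds stay as close in any read-out other than this assay and whether changes to the shared core would move the numbers further than changes at this position.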